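The source may hold more compounds than are shown below. What is called first, only, known or untested is meant among the compounds shown, and "the series" means these compounds.

In a functional assay on A549 cells (Homo sapiens) for inhibition, read by sulforhodamine B assay, with a stated time of 48 h (on this read-out higher numbers stand for weaker inhibition of growth and lower numbers for stronger inhibition of growth), compound 1 (`O=C(Cc1csc2nc(-c3ccc(Br)cc3)cn12)N/N=C/c1ccccc1O`) gives 24000 nM and compound 2 (`COc1cccc(OC)c1/C=N/NC(=O)Cc1csc2nc(-c3ccc(Br)cc3)cn12`) gives 38900 nM. These two values, the only ones measured so far, lie within the scatter of each other. Compound 3 (`O=C(Cc1csc2nc(-c3ccc(Br)cc3)cn12)N/N=C/c1ccc(Cl)cc1Cl`) carries 2,4-dichlorophenyl in place of 2,6-dimethoxyphenyl on a carbon with a double bond to nitrogen. Going by the values given here, the only measured step at that place, a 1.6-fold higher number from compound 1 to compound 2 (0.21 log units; within the scatter), stayed within the scatter, so no step beyond the scatter is expected in this assay. The estimate for compound 3 is 28000 nM, with an expected range of 12000 nM to 70000 nM. This corresponds to an expected 1.4-fold lower number from compound 2 to compound 3 (0.14 log units; within the scatter).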

Compound 3, concentration for total growth inhibition: 37200 nM
The estimate for compound 3 lay 1.3-fold (0.12 log units) below the measured number; low and high end bracket the measured number.
By their numbers in this assay, from the lowest: compounds 1, 3 and 2 (each within the scatter of the next).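

Replacing 2,6-dimethoxyphenyl with 2,4-dichlorophenyl on a carbon with a double bond to nitrogen exchanges a group with two hydrogen-bond acceptors for one with none, yet this assay shows only a 1.0-fold lower number from compound 2 to compound 3 (0.02 log units; within the scatter) and, against the 2-hydroxyphenyl group, a 1.6-fold higher number from compound 1 to compound 3 (0.19 log units; within the scatter). At this position, then, a chlorine-bearing phenyl stands within the scatter of both oxygen-bearing phenyl groups. Nothing measured accounts for this.

Going by these compounds, whether this position tolerates every change remains open. An amine or carboxylic acid on the phenyl ring, or a longer chain in its place, could still move the number beyond the scatter.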